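Aromatic Substituent Change on the Shared Core: Acid Dissociation Notes

A few compounds are considered here, and "the series" means these few. Any claim that something is new, unique, unknown or untested is made for them only; others in the source may bear on it.

Measured so far:
compound 1, `COc1cccc(Oc2ccc3c(NCCCNCc4cc(F)ccc4OC)ccnc3c2)c1` — 9.28
compound 2, `COc1cccc(Oc2ccc3c(NCCCNCc4cccc(OC)c4O)ccnc3c2)c1` — 9.28
compound 3, `COc1cccc(CNCCCNc2ccnc3cc(Cc4cccc(C(F)(F)F)c4)ccc23)c1O` — 9.47

In a physicochemical assay for acid dissociation, compound 1 gives 9.28, level with compound 2 at the digits shown, the two together the lowest of the three numbers; compound 3 is the furthest from compound 1, with a number 0.19 log units higher from compound 2 to compound 3 (within the scatter).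

Compound 4, `COc1ccc(F)cc1CNCCCNc1ccnc2cc(-c3ccc(C(C)(C)C)cc3)ccc12`, differs from compound 1 in one place: 4-(tert-butyl)phenyl in place of 3-methoxyphenoxy on an aromatic carbon. The amine-bearing chain and its substituted benzyl group are left as in compound 1.

Of the two measured steps, the one on the same aromatic carbon bears on this change: a number 0.19 log units higher from compound 2 to compound 3 (within the scatter). The other, no change at the digits printed from compound 1 to compound 2 (within the scatter), alters the chain end rather than the core substituent. Both steps stayed within the scatter, so no step beyond the scatter is expected here: a number 0.07 log units higher from compound 1 to compound 4 (within the scatter).

For compound 4 in this assay the estimate is 9.35, with a range from 9.05 to 9.65.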

Compound 4, acid dissociation constant: 9.47
Compound 4: the middle estimate sits 0.12 log units below what was measured, and the stated range covers the measured number.
By their numbers in this assay, from the lowest: compounds 1, 2, 3 and 4 (each within the scatter of the next).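

In this assay the swap of 3-methoxyphenoxy for 4-(tert-butyl)phenyl on this aromatic carbon gives a number 0.19 log units higher from compound 1 to compound 4 (within the scatter), so a change at this position again stays within the scatter, now with the chain end of compound 1. The entering group has 10 carbon and no oxygen, against 2 oxygen in the group that leaves, and this exchange of atoms moves the number no further than the scatter. Nothing on hand explains the size of this step. Going by these compounds, whether an amine or a carboxylic acid on this aromatic carbon would shift the number beyond the scatter stays open.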